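A few compounds are considered here, and "the series" means these few. Any claim that something is new, unique, unknown or untested is made for them only; others in the source may bear on it.

Measured so far in a physicochemical assay for lipophilicity; a higher number here means a more lipophilic compound, a lower number a more polar compound:
- compound 1 `O=C1N=C(N2CCOCC2)CN1c1ccc(Cl)cc1`: 1.5
- compound 2 `O=C1N=C(N2CCNCC2)CN1c1ccc(Cl)cc1`: 2.3

Compound 1 stands lowest of the two. For the measured compounds named here, the only measured step is a number 0.80 log units higher from compound 1 to compound 2 (beyond the scatter), with piperazin-1-yl in place of morpholin-4-yl. It leaves the chloro group untouched, so it bears only loosely on compound 3 `O=C1N=C(N2CCOCC2)CN1c1ccc(I)cc1`.

Compound 3 differs from compound 1 by iodo in place of chloro on an aromatic carbon. Going by the values given here, no measured step covers this change. A modest rise in this assay is expected, an estimated a number 0.40 log units higher from compound 1 to compound 3 (beyond the scatter). For compound 3 the expected value is 1.9, with an estimated range of 1.5 to 2.3.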

Compound 3, partition coefficient: 1.7
The estimate for compound 3 lay 0.20 log units above the measured number; low and high end bracket the measured number.
By their numbers in this assay, from the lowest: compounds 1 and 3 (each within the scatter of the next); then compound 2.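

In this assay, iodo in place of chloro on an aromatic carbon para to a large group gives a number 0.20 log units higher from compound 1 to compound 3 (within the scatter), so this read-out does not separate the two groups at this position. For the compounds shown here, the only step beyond the scatter remains the one at the other place, a number 0.80 log units higher from compound 1 to compound 2 (beyond the scatter), where piperazin-1-yl stands in place of morpholin-4-yl. Nothing at hand offers an explanation for this result.

As far as these compounds go, whether an amine or a carboxylic acid at this position gives a step beyond the scatter stays open. Also open, from the compounds shown here alone, is whether iodo in place of chloro reads the same on the piperazin-1-yl compound 2.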